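This account rests on a few compounds, and the source may have more. Where it says the series, first, only, none or still open, it means among the compounds named here.

Compound 1 `O=C(O)c1csc(-n2nc(-c3ccccc3)c3cc(F)ccc32)n1`: 345 mL/min/kg
Compound 2 `COc1ccc2c(-c3ccccc3)nn(-c3nc(C(=O)O)cs3)c2c1`: 196 mL/min/kg
Compound 3 `O=C(O)c1csc(-n2nc(-c3ccc(F)cc3)c3ccccc32)n1`: 278 mL/min/kg

In an ADME assay (liver) for metabolic stability, with Liver microsome (Rattus norvegicus) as the target, using microsomes (on this read-out higher numbers stand for fast clearance and lower numbers for slow clearance), compound 3 gives 278 mL/min/kg. This value lies within the usual scatter of the other two, so these three compounds cannot be ranked against one another. Compound 4 `O=C(O)c1csc(-n2nc(-c3ccc(Cl)cc3)c3ccccc32)n1` has chloro in place of fluoro on an aromatic carbon, para to a large group: chloro in place of fluoro on an aromatic carbon. Within the data shown here, no two measured compounds differ in one place only, so this swap has no direct precedent here. The expected 1.0-fold higher number from compound 3 to compound 4 (0.02 log units; within the scatter) is small, with no change in either direction expected beyond the scatter. Compound 4 is estimated at 290 mL/min/kg, with an expected range from 170 mL/min/kg to 500 mL/min/kg.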

Compound 4, clearance: 753 mL/min/kg
Compound 4: the middle estimate sits 2.6-fold (0.41 log units) below what was measured; measured number outside the range, above it.
By their numbers in this assay, from the lowest: compounds 2, 3 and 1 (each within the scatter of the next); then compound 4.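

Among these compounds, the only pair here that differs in one place is compound 3 and compound 4, and in this assay 4-fluorophenyl to 4-chlorophenyl gives a 2.7-fold higher number from compound 3 to compound 4 (0.43 log units; beyond the scatter) in clearance. This position, on an aromatic carbon para to a large group, therefore does not treat the two halogens alike, although both are single-atom groups without hydrogen-bond donors or acceptors. Nothing available here accounts for the rise.

Still open, on these data alone, is whether a bromo or a methyl group at this position would stay close to compound 3 or climb towards compound 4. A single pair also cannot show whether the same swap would act alike on another part of the shared core.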